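The compounds below may be only part of what the source reports. "The series", "measured", "known", "first", "only" and "open" are said of these compounds alone.

Compound 1 `C=C1C[C@]23C[C@@]1(O)CC[C@H]2c1ccc(OS(=O)(=O)c2ccc(C)cc2)c(C)c1[C@@H]3Cn1cc(-c2ccc(F)cc2)nn1` carries the shared core of this set. In a functional assay on MCF7 cells (Homo sapiens) for cytotoxicity, read by MTT assay, with a stated time of 4 days (on this read-out higher numbers stand for weaker inhibition and lower numbers for stronger inhibition), compound 1 reaches only a limit of the assay, > 20000 nM. Compound 2 `C=C1C[C@]23C[C@@]1(O)CC[C@H]2c1ccc(OS(=O)(=O)c2ccc(C)cc2)c(C)c1[C@@H]3Cn1cc(-c2ccc(C(F)(F)F)cc2)nn1` differs from it by a trifluoromethyl in place of fluoro on an aromatic carbon. In this assay compound 2 likewise returns a limit and no number, > 20000 nM. The step that the two limits leave unreadable from compound 1 to compound 2 therefore cannot be read in size or direction, and compound 2 stands at the limit of > 20000 nM in this assay, at which 2 of the 2 values shown sit, with nothing that sets it apart from compound 1. Compound 3 `C=C1C[C@]23C[C@@]1(O)CC[C@H]2c1ccc(OS(=O)(=O)c2ccc(C)cc2)c(C)c1[C@@H]3Cn1cc(-c2ccccn2)nn1` carries a further change: pyridin-2-yl in place of 4-(trifluoromethyl)phenyl on an aromatic carbon. Among the measured compounds shown here, no measured step bears directly on this exchange; the only step in hand, a step that the two limits leave unreadable from compound 1 to compound 2, is itself unreadable, so neither a size nor a direction can be drawn from the numbers so far. The expected step is a number no higher from compound 2 to compound 3 (the limit leaves the size open), that is, no movement beyond the scatter in this assay. Compound 3 is accordingly estimated at 20000 nM, within 7000 nM to 60000 nM, and most likely once more reported as a limit rather than a number.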

Compound 3, half-maximal inhibitory concentration: > 20000 nM
Compound 3 was reported as a limit; the forecaster's own chance of this, stated with the estimate: 70%; the middle value lies on the limit itself.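

Compound 1, compound 2 and compound 3 all return only a limit in this assay, so no step among them can be read in size or direction: the limit of > 20000 nM in this assay, at which 3 of the 3 values shown sit.

The compounds shown leave open whether exchanging the group on this aromatic carbon alters the read-out at all, and at what concentration any of the three would reach half-maximal inhibition.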